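Swapping fluorophenyl for thiophene where nothing yet registers

The source may hold more compounds than are shown below. What is called first, only, known or untested is meant among the compounds shown, and "the series" means these compounds.

All compounds share the core of compound 1 `CC1=CC[C@H](C(C)(C)NC(=S)NN)CC1`, for which a functional assay on UACC-62 cells (Homo sapiens) for inhibition, read by sulforhodamine B assay, with a stated time of 48 h (on this read-out lower numbers stand for stronger inhibition of growth and higher numbers for weaker inhibition of growth), reports no result: compound 1 stands at "not determined" (no result reported). Compound 2 `CC1=CC[C@H](C(C)(C)NC(=S)N/N=C/c2ccccc2)CC1` does not reach a number in this assay; compound 2 reports only the limit > 100000 nM. Compound 3 `CC1=CC[C@H](C(C)(C)NC(=S)N/N=C/c2ccc(F)cc2)CC1` likewise reports only the limit > 100000 nM in this assay. The step that the two limits leave unreadable from compound 2 to compound 3 therefore has no readable size, because both entries sit at the limit of > 100000 nM in this assay, at which 2 of the 3 values shown sit. Compound 4 `CC1=CC[C@H](C(C)(C)NC(=S)N/N=C/c2cccs2)CC1` differs from compound 3 by thiophen-2-yl in place of 4-fluorophenyl on a carbon with a double bond to nitrogen. Going by the values given here, no measured step gives a readable size, so no direction beyond the scatter can be drawn from the data. Compound 4 is therefore expected near 100000 nM, with a range from 30000 nM to 300000 nM. The step of a number no higher from compound 3 to compound 4 (the limit leaves the size open) is estimated as none beyond the scatter.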

Compound 4, concentration for total growth inhibition: 19000 nM
Estimate against measurement, compound 4: 5.3-fold (0.72 log units) above; measured number outside the range, below it.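

At this carbon with a double bond to nitrogen, the ring group can move growth inhibition in this assay to a measurable level. Thiophen-2-yl in place of 4-fluorophenyl gives an at least 5.2-fold lower number from compound 3 to compound 4 (0.72 log units; beyond the scatter), and in place of phenyl it gives an at least 5.2-fold lower number from compound 2 to compound 4 (0.72 log units; beyond the scatter). The full size of both steps stays open, and the step between the two six-membered rings cannot be read, because those compounds stop at a limit: the limit of > 100000 nM in this assay, at which 2 of the 4 values shown sit.

The compounds shown leave open whether another five-membered aromatic ring, such as furan-2-yl, would act like thiophen-2-yl. They also leave open what an amine on the phenyl ring would do.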